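This account rests on a few compounds, and the source may have more. Where it says the series, first, only, none or still open, it means among the compounds named here.

The shared core of compound 1 `O=c1[nH]cc(S(=O)(=O)Nc2ccccc2-c2cn(-c3ccccc3)nn2)c(=O)[nH]1` carries a plain phenyl on an aromatic nitrogen, and in a functional assay on OVCAR-3 cells (Homo sapiens) for antiproliferative activity, read by MTT assay, with a stated time of 24 h (a higher number here means a weaker inhibitor, a lower number a stronger inhibitor), compound 1 gives 6650 nM. Compound 2 `O=c1[nH]cc(S(=O)(=O)Nc2ccccc2-c2cn(-c3ccccc3F)nn2)c(=O)[nH]1` carries a 2-fluorophenyl there; in this assay compound 2 gives 15300 nM, a change of a 2.3-fold higher number from compound 1 to compound 2 (0.36 log units; beyond the scatter). Compound 3 `O=c1[nH]cc(S(=O)(=O)Nc2ccccc2-c2cn(-c3cccc(F)c3)nn2)c(=O)[nH]1` carries a 3-fluorophenyl. For compound 3 this assay reports only a limit, > 20000 nM. Compound 3 therefore sits at the high end of the numbers shown, with an at least 3.0-fold higher number from compound 1 to compound 3 (0.47 log units; beyond the scatter) and an at least 1.3-fold higher number from compound 2 to compound 3 (0.11 log units; that floor lies within the scatter). Compound 4 `O=c1[nH]cc(S(=O)(=O)Nc2ccccc2-c2cn(-c3cccc(Cl)c3)nn2)c(=O)[nH]1` differs from compound 3 by chloro in place of fluoro on an aromatic carbon. Among the measured compounds shown here, no measured step exchanges one halogen for another; both fluoro steps from compound 1 raised the number, and compound 3 already stands at the limit of > 20000 nM in this assay, at which 1 of the 3 values shown sits. One therefore expects no step beyond the scatter from compound 3 to compound 4, a step that the limit leaves unreadable from compound 3 to compound 4, and most probably a further limit rather than a number. Compound 4 is estimated at 25000 nM, in a range from 12000 nM to 60000 nM.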

Compound 4, half-maximal inhibitory concentration: 2180 nM
Estimate against measurement, compound 4: 11-fold (1.06 log units) above, outside the stated range (below it).
By their numbers in this assay, from the lowest: compound 4; then compound 1; then compound 2. At a limit, above all of these: compound 3.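

Exchanging fluoro for chloro on this aromatic carbon reverses the direction of both fluoro steps in this assay and gives an at least 9.1-fold lower number from compound 3 to compound 4 (0.96 log units; beyond the scatter) as a floor on the size of the change. Compound 3 is held only at a limit of the assay: the limit of > 20000 nM in this assay, at which 1 of the 4 values shown sits. Chloro at this place also gives a 3.1-fold lower number from compound 1 to compound 4 (0.48 log units; beyond the scatter) and a 7.0-fold lower number from compound 2 to compound 4 (0.85 log units; beyond the scatter) so a halogen on this phenyl does not by itself raise the number, and compound 4 is the strongest of the four compounds, with all its steps beyond the scatter.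

The compounds shown leave open whether bromo, methyl or methoxy at this place would follow chloro or fluoro, and whether an amine or a carboxylic acid there would keep the number low. They also leave open whether the gain from chloro extends to other cell lines.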